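The source may hold more compounds than are shown below. What is called first, only, known or untested is meant among the compounds shown, and "the series" means these compounds.

Among the compounds with values here, in a functional assay on 518A2 cells (Homo sapiens) for inhibition, read by MTT assay, with a stated time of 72 h (on this read-out lower numbers stand for stronger inhibition and higher numbers for weaker inhibition), two compounds with the same core have numbers so far. Compound 1 `COc1cc(/C=C/C(=O)c2ccc3ccccc3c2)cc(Br)c1OC`, which carries a bromo group, gives 20200 nM, and compound 2 `COc1cc(/C=C/C(=O)c2ccc3ccccc3c2)cc(I)c1OC`, which carries iodo on the same aromatic carbon, gives 18100 nM. Within the data shown here, the one measured step is a 1.1-fold lower number from compound 1 to compound 2 (0.05 log units; within the scatter), so compound 2 stands level with compound 1 on these numbers.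

The next structure, compound 3 `COc1cc(/C=C/C(=O)c2ccc3ccccc3c2)cc(OC)c1OC`, changes that same carbon again, with methoxy in place of iodo on an aromatic carbon. Among the measured compounds shown here, only the step from bromo to iodo bears on this change, and it is an imperfect guide, since no measured compound has anything but bromo or iodo at this carbon. Still, that exchange, seen in a 1.1-fold lower number from compound 1 to compound 2 (0.05 log units; within the scatter), left the number within the scatter. The expectation in this assay is therefore a small step with no firm direction, probably not beyond the scatter, although a larger move cannot be excluded. Compound 3 is thus expected to show a 1.2-fold lower number from compound 2 to compound 3 (0.08 log units; within the scatter). For compound 3 the estimated value is 15000 nM, with an expected range of 5000 nM to 40000 nM.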

Compound 3, half-maximal inhibitory concentration: 22900 nM
Compound 3: middle estimate off by 1.5-fold (0.18 log units), on the low side; the range from low to high includes it.
By their numbers in this assay, from the lowest: compounds 2, 1 and 3 (each within the scatter of the next).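

In this assay, replacing a halogen with methoxy gives a 1.3-fold higher number from compound 2 to compound 3 (0.10 log units; within the scatter) and a 1.1-fold higher number from compound 1 to compound 3 (0.05 log units; within the scatter) and so leaves all three compounds level. The earlier pair showed this only for an exchange of bromo and iodo, whereas this change swaps iodo, a single heavy atom with 0 hydrogen-bond acceptors, for methoxy, with 2 heavy atoms and 1 hydrogen-bond acceptor, and the number on this read-out still does not separate. At this aromatic carbon, then, these three groups cannot be told apart in this assay, and no supporting measurement is available to explain why.

Going by these compounds, it remains open whether a group of another kind at this carbon, such as an amine, a carboxylic acid or a longer chain like butoxy, would move the number beyond the scatter in either direction. The compounds shown also leave open whether this carbon would stay just as undiscriminating if another part of the shared core were changed.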